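This account rests on a few compounds, and the source may have more. Where it says the series, first, only, none or still open, it means among the compounds named here.

Measured compounds:
- compound 1, `Cc1ccnc(NC[C@@H]2CC3(CC3)CN2C(=O)c2nc(C)sc2-c2ccccc2)n1`: 7
- compound 2, `Cc1ccc(OCc2ccccc2)c(C(=O)N2CC3(CC3)C[C@H]2CNc2ccc(C(F)(F)F)cn2)n1`: 8.6

In a functional assay on HEK293 cells for antagonist activity at Orexin receptor type 2 (Homo sapiens), read by FLIPR and calcium flux (a higher number here means a more potent compound, by a factor of ten per unit of this negative logarithm, a lower number a less potent compound), compound 1 stands lower than compound 2, and the gap between the two lies beyond the usual scatter. Compound 3, `Cc1nc(C(=O)N2CC3(CC3)C[C@H]2CNc2ccc(C(F)(F)F)cn2)c(-c2ccccc2)s1`, keeps the core of compound 1 and carries the change (5-(trifluoromethyl)pyridin-2-yl in place of 4-methylpyrimidin-2-yl on an amine nitrogen); compound 2 bears the same entering group on a different core. Among the measured compounds shown here, since no step between measured compounds is available, the expectation rests on the higher value of compound 2 with 8.6: compound 3 is expected to gain in this assay, moving by a number 0.80 log units higher from compound 1 to compound 3 (beyond the scatter) to an estimated 7.8, with a range from 7.2 to 8.5.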

Compound 3, negative logarithm of the antagonist equilibrium constant: 7.7
Beside the measured number, compound 3's estimate is 0.10 log units above it, and the stated range covers the measured number.
By their numbers in this assay, from the lowest: compound 1; then compound 3; then compound 2.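

In this assay, with the core of compound 1 held fixed, placing 5-(trifluoromethyl)pyridin-2-yl in place of 4-methylpyrimidin-2-yl on the amine nitrogen gives a change of a number 0.70 log units higher from compound 1 to compound 3 (beyond the scatter). This single-place comparison shows that the group on this nitrogen alone can shift potency beyond the usual scatter, which the two earlier compounds, differing in more than one place, could not show. Nothing available bears on the reason for this gain.

On these data alone, it remains open whether the trifluoromethyl group itself matters, since the ring changes with it. A plain pyridin-2-yl, or a pyridin-2-yl carrying a nitrile in place of trifluoromethyl, would help separate the two.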